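Aminomethyl in place of (dimethylcarbamoyl)methyl on a coumarin-like core

This account rests on a few compounds, and the source may have more. Where it says the series, first, only, none or still open, it means among the compounds named here.

Measured compounds:
compound 1, `C[C@H](Nc1cc(=O)oc2cc(OCc3ccccc3)ccc12)C(N)=O`, 680 nM
compound 2, `NC(=O)Cc1cc(=O)oc2cc(OCc3ccccc3)ccc12`, 200 nM
compound 3, `CN(C)C(=O)Cc1cc(=O)oc2cc(OCc3ccccc3)ccc12`, 400 nM

These three compounds were tested in an assay for inhibition of Amine oxidase [flavin-containing] B (Rattus norvegicus); a higher number here means a weaker inhibitor, a lower number a stronger inhibitor. Among them, compound 3 gives the second highest number of the three: its nearest neighbour is compound 1, with a 1.7-fold lower number from compound 1 to compound 3 (0.23 log units; within the scatter), and its furthest is compound 2, with a 2.0-fold higher number from compound 2 to compound 3 (0.30 log units; within the scatter). Within the data shown here, only the step of a 3.4-fold lower number from compound 1 to compound 2 (0.53 log units; beyond the scatter) lies beyond the usual scatter of this assay.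

Compound 4, `NCc1cc(=O)oc2cc(OCc3ccccc3)ccc12`, has not yet been measured. It differs from compound 3 by amino in place of dimethylcarbamoyl on a saturated chain carbon bound to an aromatic carbon. Of the measured steps, a 2.0-fold higher number from compound 2 to compound 3 (0.30 log units; within the scatter) is the closest in kind, since it also alters the group attached to the carbonyl carbon, and it stays within the scatter. Among the measured compounds shown here, the step to compound 4 removes the carbonyl altogether, for which no measured pair gives a direct precedent, so the expectation rests only on the small spread of the three numbers.

On that basis compound 4 is expected to give roughly 500 nM in this assay, within a range of 150 nM to 1600 nM, which would mean an estimated step of a 1.3-fold higher number from compound 3 to compound 4 (0.10 log units; within the scatter), not clearly beyond the scatter in either direction.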

Compound 4, half-maximal inhibitory concentration: 21 nM
The estimate for compound 4 lay 24-fold (1.38 log units) above the measured number; the measured number lies below the stated range.
By their numbers in this assay, from the lowest: compound 4; then compounds 2, 3 and 1 (each within the scatter of the next, the first and the last beyond it).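

In this assay, among these compounds, the earlier compounds showed only that changing the group on the carbonyl carbon of this side chain left the number within the scatter (a 2.0-fold higher number from compound 2 to compound 3 (0.30 log units; within the scatter)). Replacing the whole carbonyl-bearing group with amino on the saturated chain carbon bound to an aromatic carbon has a much larger effect, seen both with dimethylcarbamoyl as the group replaced (a 19-fold lower number from compound 3 to compound 4 (1.28 log units; beyond the scatter)) and with carbamoyl (a 9.5-fold lower number from compound 2 to compound 4 (0.98 log units; beyond the scatter)). The same holds against the side chain of compound 1 when aminomethyl takes the place of (1-carbamoylethyl)amino on an aromatic carbon (a 32-fold lower number from compound 1 to compound 4 (1.51 log units; beyond the scatter)), which makes compound 4 the strongest inhibitor of the four, with its steps to all three others beyond the scatter.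

The compounds shown do not separate the gain from the amino group from that of losing the carbonyl, and a hydroxymethyl group, a dimethylaminomethyl group or a longer aminoethyl chain in the same place would be needed to tell these apart. No evidence is available here that accounts for the size of this step.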